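A few compounds are considered here, and "the series" means these few. Any claim that something is new, unique, unknown or untested is made for them only; others in the source may bear on it.

Compound 1 `COc1ccc(-c2ccnc(Nc3ccc4c(c3)c(/C=C3/C(=O)Nc5ccccc53)cn4C)n2)cc1` gives a limit in a functional assay on PA-1 cells (Homo sapiens) for cytotoxicity, read by MTT assay, with a stated time of 48 h (on this read-out lower numbers stand for stronger inhibition and higher numbers for weaker inhibition), of > 100000 nM.
Compound 2 `Cn1cc(/C=C2/C(=O)Nc3ccccc32)c2cc(Nc3nccc(-c4ccc(O)cc4)n3)ccc21` gives 9270 nM in this assay.
Compound 3 `Cn1cc(/C=C2/C(=O)Nc3ccccc32)c2cc(Nc3nccc(-c4ccc(Cl)cc4)n3)ccc21` gives 2430 nM in this assay.

Compound 3 stands lowest of the two numbers shown in this assay, the other being compound 2, while compound 1 sits at a limit (the limit of > 100000 nM in this assay, at which 1 of the 3 values shown sits). The steps measured all concern the para substituent of the pendant phenyl ring: an at least 10-fold lower number from compound 1 to compound 2 (1.03 log units; beyond the scatter), an at least 41-fold lower number from compound 1 to compound 3 (1.61 log units; beyond the scatter) and a 3.8-fold lower number from compound 2 to compound 3 (0.58 log units; beyond the scatter). Compound 4 `Cn1cc(/C=C2/C(=O)Nc3ccccc32)c2cc(Nc3nccc(-c4cccnc4)n3)ccc21` has not yet been measured in this assay. It differs from compound 3 in that (pyridin-3-yl in place of 4-chlorophenyl on an aromatic carbon). Among the compounds with values here, no measured step replaces this ring with a heteroaromatic one, so the nearest guides are the changes at the same ring in compounds 1, 2 and 3, where the chloro analogue gave the lowest number and the hydroxy and methoxy analogues higher ones. On that basis compound 4 is expected to give a higher number than compound 3, a step of a 3.3-fold higher number from compound 3 to compound 4 (0.52 log units; beyond the scatter), and its value in this assay is estimated at 8000 nM, with a range from 2500 nM to 30000 nM.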

Compound 4, half-maximal inhibitory concentration: 18100 nM
Compound 4: the middle estimate sits 2.3-fold (0.35 log units) below what was measured; the range from low to high includes it.
By their numbers in this assay, from the lowest: compound 3; then compounds 2 and 4 (each within the scatter of the next). At a limit, above all of these: compound 1.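

In this assay, exchanging the whole ring at this position, pyridin-3-yl in place of 4-chlorophenyl, gives a 7.4-fold higher number from compound 3 to compound 4 (0.87 log units; beyond the scatter), so the low number of compound 3 does not carry over to this ring with a hetero atom. Set against the other two rings, pyridin-3-yl gives a 2.0-fold higher number from compound 2 to compound 4 (0.29 log units; within the scatter) and an at least 5.5-fold lower number from compound 1 to compound 4 (0.74 log units; beyond the scatter), which leaves it not separable from 4-hydroxyphenyl but clear of 4-methoxyphenyl. Compound 1 sits at a limit, so that last step is a bound only: the limit of > 100000 nM in this assay, at which 1 of the 4 values shown sits.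

The compounds shown leave open whether the higher number of compound 4 goes with the ring nitrogen or with the loss of the chloro group, which a plain phenyl ring would separate. Also open, going by these compounds, is whether a pyridin-4-yl, 4-fluorophenyl or 4-aminophenyl ring would fall nearer compound 3 or compound 4.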